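The source may hold more compounds than are shown below. What is called first, only, known or untested is meant among the compounds shown, and "the series" means these compounds.

Among the measured compounds shown here, in a functional assay on HL-60 cells (Homo sapiens) for inhibition, read by MTT assay, with a stated time of 48 h, tested at 10 uM (a lower number here means less inhibition of growth, a higher number more inhibition of growth at the concentration tested), compound 2 (`CCOC(=O)N1CCN(Cc2c(O)c([C@H]3CCN(C)C[C@H]3O)c3oc(C)cc(=O)c3c2O)CC1`) gives 16%, the lower of the two numbers so far, and compound 1 (`Cc1cc(=O)c2c(O)c(CN3CCCC3)c(O)c([C@H]3CCN(C)C[C@H]3O)c2o1`) gives 38%. Compound 3 (`Cc1cc(=O)c2c(O)c(CN3CCCC3C(=O)O)c(O)c([C@H]3CCN(C)C[C@H]3O)c2o1`) keeps the shared core and changes one group: 2-carboxypyrrolidin-1-yl in place of 4-(ethoxycarbonyl)piperazin-1-yl on a saturated chain carbon bound to an aromatic carbon. For the measured compounds named here, the only measured step at this place is a number 22 percentage points lower from compound 1 to compound 2 (beyond the scatter), a modest one. The incoming group resembles the pyrrolidin-1-yl of compound 1, but no measurement shows what its carboxy part does, so only a small part of that step is expected to return. The expected change is a number 6 percentage points higher from compound 2 to compound 3 (within the scatter), upward but not clearly beyond the scatter. For compound 3 the estimated value is 22%, within a range of 8% to 40%.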

Compound 3, percent growth inhibition at one concentration: 16%
The estimate for compound 3 lay 6 percentage points above the measured number; measured number inside the range.
By their numbers in this assay, from the lowest: compounds 2 and 3 (each within the scatter of the next); then compound 1.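

In this assay carboxy on a saturated ring carbon brings a number 22 percentage points lower from compound 1 to compound 3 (beyond the scatter), so a lower number at this place does not depend on 4-(ethoxycarbonyl)piperazin-1-yl alone. The exchange of that group for 2-carboxypyrrolidin-1-yl gives no change at the digits printed from compound 2 to compound 3 (within the scatter), although the two differ in ring size and hetero atoms. Nothing measured on these compounds gives a reason for either step.

Going by these compounds, it remains open whether a methyl ester or an amide on that same ring carbon would read like the carboxy group. On these data alone, whether piperidin-1-yl would stay near pyrrolidin-1-yl is also open.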